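Chain extension on the hydrazone of a nitrothiazole series

The compounds below may be only part of what the source reports. "The series", "measured", "known", "first", "only" and "open" are said of these compounds alone.

The measured compounds and their values in an assay on isolated protein for inhibition of Amine oxidase [flavin-containing] A (Homo sapiens), read by fluorescence, with a stated time of 20 min; a lower number here means a stronger inhibitor, a higher number a weaker inhibitor:
- compound 1, `CC(C)=NNc1nc(-c2cccc([N+](=O)[O-])c2)cs1`: 1070 nM
- compound 2, `CCC/C(C)=N\Nc1nc(-c2cccc([N+](=O)[O-])c2)cs1`: 38000 nM
- compound 3, `CCC(CC)=NNc1nc(-c2cccc([N+](=O)[O-])c2)cs1`: 24300 nM

Compound 2 gives the highest number of the three in this assay. Compound 3 sits closest to it, and the step of a 1.6-fold lower number from compound 2 to compound 3 (0.19 log units; within the scatter) stays within the scatter, so the two cannot be ordered. Compound 1 stands furthest away, with a 36-fold higher number from compound 1 to compound 2 (1.55 log units; beyond the scatter) and a 23-fold higher number from compound 1 to compound 3 (1.36 log units; beyond the scatter) both well beyond the scatter.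

Compound 4, `CCCCCC/C(C)=N\Nc1nc(-c2cccc([N+](=O)[O-])c2)cs1`, has not yet been measured. It differs from compound 2 in one place: propyl in place of hydrogen on a saturated chain carbon, three bonds along the chain from a carbon with a double bond to nitrogen.

Among the compounds with values here, two measured steps bear on this change. From compound 1 to compound 2 a longer saturated chain was introduced and the number rose sharply, and from compound 1 to compound 3 a similar enlargement gave a comparable rise. From compound 2 to compound 3 a rearrangement of the same chain size left the number where it was. Adding three more carbons to the chain of compound 2 is therefore expected to leave the number about where it is or push it somewhat higher, with no expectation of a return toward compound 1.

Compound 4 is estimated at 60000 nM, with a range from 15000 nM to 200000 nM, which is an expected step of a 1.6-fold higher number from compound 2 to compound 4 (0.20 log units; within the scatter).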

Compound 4, half-maximal inhibitory concentration: 10900 nM
Compound 4: middle estimate off by 5.5-fold (0.74 log units), on the high side; measured number outside the range, below it.
By their numbers in this assay, from the lowest: compound 1; then compound 4; then compounds 3 and 2 (each within the scatter of the next).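

In this assay, the number does not climb steadily as the chain grows: propyl in place of hydrogen on a saturated chain carbon, three bonds along the chain from a carbon with a double bond to nitrogen, gives a 3.5-fold lower number from compound 2 to compound 4 (0.54 log units; beyond the scatter), a modest fall beyond the scatter. The longer chain therefore recovers only part of what was lost, as a 10-fold higher number from compound 1 to compound 4 (1.01 log units; beyond the scatter) remains a large step and compound 1 keeps the lowest number of the compounds compared here. No supporting evidence is available to explain why the longer chain of compound 4 gives a lower number than the shorter chain of compound 2.

The compounds shown leave open whether a chain longer than that of compound 4 would lower the number further, hold it level or raise it again, so the single step from compound 2 to compound 4 cannot define a trend. They also leave open whether an amine, a carboxylic acid or a phenyl ring at the far end of the chain would change the number in this assay.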